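This account rests on a few compounds, and the source may have more. Where it says the series, first, only, none or still open, it means among the compounds named here.

In an assay on HEK293 cells for inhibition of N-acylethanolamine-hydrolyzing acid amidase (Rattus norvegicus), read by LC-MS, with a stated time of 30 min (on this read-out higher numbers stand for weaker inhibition and lower numbers for stronger inhibition), compound 1 `NC(=O)c1ccc(CCCCCC(=O)N2CCOC2=O)cc1` reaches only the limit of the assay, > 20000 nM. Compound 2 `O=C1OCCN1C(=O)c1ccc(Oc2ccc(O)cc2)cc1` likewise gives only a limit in this assay, > 20000 nM. Both values sit at the limit of > 20000 nM in this assay, at which 2 of the 2 values shown sit, so compound 2 stands at the weak end of what the assay can report, with nothing to separate it from compound 1. Compound 3 `O=C1OCCN1C(=O)c1ccc(OC2CCOCC2)cc1` differs from compound 2 by oxan-4-yl in place of 4-hydroxyphenyl on an oxygen on an aromatic ring. Going by the values given here, no measured pair shows the effect of such a change. The step from compound 2 to compound 3 is expected to be none beyond the scatter, at a step that the limit leaves unreadable from compound 2 to compound 3. Compound 3 is estimated to give 25000 nM, within a range from 8000 nM to 80000 nM, most likely again only as a limit.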

Compound 3, half-maximal inhibitory concentration: 330 nM
Estimate against measurement, compound 3: 76-fold (1.88 log units) above; the whole stated range lies above it.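

Placing oxan-4-yl instead of 4-hydroxyphenyl on the oxygen on an aromatic ring gives an at least 60-fold lower number from compound 2 to compound 3 (1.78 log units; beyond the scatter) in this assay. The group on this oxygen can therefore decide whether the core shows a readable inhibition at all, which the two limits alone could not show. As far as these compounds go, the true size of the step stays unknown, as compound 2 gives only a limit: the limit of > 20000 nM in this assay, at which 2 of the 3 values shown sit.

The change swaps an aromatic ring for a non-aromatic one and also removes a hydrogen-bond donor, and the compounds shown cannot separate these two differences. From the compounds shown here alone, how a cyclohexyl or an unsubstituted phenyl group on this oxygen would compare remains open.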